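The compounds below may be only part of what the source reports. "The series", "measured", "known", "first", "only" and "open" are said of these compounds alone.

Compound 1 `COc1cc(C(=O)Nc2nn[nH]n2)nc(-c2ccc(C)cc2)c1`: 42%. Compound 2 `Cc1ccc(-c2cccc(C(=O)Nc3nn[nH]n3)n2)cc1`: 67%. Compound 3 `Cc1cccc(-c2cc(C)cc(C(=O)Nc3nn[nH]n3)n2)c1`: 51%.

All three were tested in a functional assay on the whole organism with Rattus norvegicus as the target, at a dose of 1 mg/kg by the oral route; on this read-out higher numbers stand for a stronger effect at the one dose given and lower numbers for a weaker effect. Compound 3 stands second highest of the three numbers: its value lies within the scatter of that of compound 1 and beyond the scatter below that of compound 2. Compound 4 `Cc1ccc(-c2cc(C)cc(C(=O)Nc3nn[nH]n3)n2)cc1` has not yet been measured; it differs from compound 3 in one place: 4-methylphenyl in place of 3-methylphenyl on an aromatic carbon. Going by the values given here, the only measured step, a number 25 percentage points higher from compound 1 to compound 2 (beyond the scatter), concerns a different change and does not bear on this one. Among the compounds with values here, compound 2, which also carries 4-methylphenyl, gives 67%, whereas compound 3 gives 51%; no step between them is computed. The step of a number 6 percentage points higher from compound 3 to compound 4 (within the scatter) is therefore expected to be small, with wide uncertainty. Compound 4 is estimated at 57%, between 35% and 78%.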

Compound 4, a percentage reported as inhibition, in the whole organism at one dose (the size of the read-out at that dose, not a potency): 80%
Beside the measured number, compound 4's estimate is 23 percentage points below it; measured number outside the range, above it.
By their numbers in this assay, from the lowest: compounds 1 and 3 (each within the scatter of the next); then compound 2; then compound 4.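

In this assay, 4-methylphenyl in place of 3-methylphenyl gives a number 29 percentage points higher from compound 3 to compound 4 (beyond the scatter), so the placing of one methyl on this aryl group, with the atom count unchanged, changes the read-out beyond the scatter. With 4-methylphenyl held fixed, methyl on the aromatic carbon of the core gives a number 13 percentage points higher from compound 2 to compound 4 (beyond the scatter) against hydrogen and a number 38 percentage points higher from compound 1 to compound 4 (beyond the scatter) against methoxy, so among these three compounds methyl gives the highest number at that carbon. No available evidence accounts for these differences. Still open, going by these compounds, is how 4-ethylphenyl would read at the aryl position, and how an amine would read in place of that methyl.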